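This account rests on a few compounds, and the source may have more. Where it says the series, first, only, none or still open, it means among the compounds named here.

Measured so far:
compound 2 `CC(C)(C)OC(=O)N1CCN(CC(=O)Nc2ccc(C(=O)/C=C/c3cn(Cc4ccc(Br)cc4)nn3)cc2)CC1`, 31000 nM in a functional assay on MCF7 cells (Homo sapiens) for inhibition, read by MTT assay; on this read-out lower numbers stand for stronger inhibition and higher numbers for weaker inhibition
compound 1 `CCCCCCCCCCn1cc(/C=C/C(=O)c2ccc(NC(=O)CN3CCN(c4ccccc4)CC3)cc2)nn1`, > 100000 nM in this assay, which is a limit of the assay rather than a number

For the measured compounds named here, compound 2 is thus the only compound with an actual number in this assay. Compound 3 `CCCCCCCCCCn1cc(/C=C/C(=O)c2ccc(NC(=O)CN3CCN(C(=O)OC(C)(C)C)CC3)cc2)nn1` differs from compound 2 by nonyl in place of 4-bromophenyl on a saturated chain carbon bound to an aromatic nitrogen; cut one bond further out, the same change reads 4-bromobenzyl to decyl. Going by the values given here, no measured pair shows this change. Compound 1, which also carries the decyl chain, sits at the limit of > 100000 nM in this assay, at which 1 of the 2 values shown sits. With that in mind, compound 3 is expected to lose potency, a step of a 2.9-fold higher number from compound 2 to compound 3 (0.46 log units; beyond the scatter). For compound 3 the estimate is 90000 nM, ranging from 25000 nM to 300000 nM.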

Compound 3, half-maximal inhibitory concentration: 40000 nM
For compound 3 the middle estimate is 2.3-fold (0.35 log units) above the measured one; the measured number falls inside the stated range.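

On the saturated chain carbon bound to an aromatic nitrogen, nonyl in place of 4-bromophenyl gives a 1.3-fold higher number from compound 2 to compound 3 (0.11 log units; within the scatter) in this assay, so here the ring-bearing group and the long chain cannot be told apart. With decyl kept, tert-butoxycarbonyl in place of phenyl on the amine nitrogen in a ring gives an at least 2.5-fold lower number from compound 1 to compound 3 (0.39 log units; beyond the scatter), so this second site does register a change. Compound 1 supplies only a limit, not a number: the limit of > 100000 nM in this assay, at which 1 of the 3 values shown sits.

Still open, going by these compounds, is how a shorter chain would read at the first site. Also open, on these data alone, is how a free amine or a carboxylic acid would read at the second.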